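This account rests on a few compounds, and the source may have more. Where it says the series, first, only, none or still open, it means among the compounds named here.

Among the compounds with values here, in an ADME assay on MT4 cells (Homo sapiens) for cytotoxicity, read by MTT assay, with a stated time of 5 days (a higher number here means that more compound is tolerated, a lower number that less compound is tolerated), compound 1 (`COc1cc2nc([S+]([O-])CC(=O)Nc3cccc(C(F)(F)F)c3)nc(Nc3c(Cl)cc(/C=C/C#N)cc3Cl)c2cc1OC`) gives 21800 nM and compound 2 (`COc1cc2nc([S+]([O-])CC(=O)Nc3ccc(C(F)(F)F)cc3)nc(Nc3c(Cl)cc(/C=C/C#N)cc3Cl)c2cc1OC`) gives 22000 nM so compound 2 stands level with its only neighbour. Compound 3 (`COc1cc2nc([S+]([O-])CC(=O)Nc3cccc(S(N)(=O)=O)c3)nc(Nc3c(Cl)cc(/C=C/C#N)cc3Cl)c2cc1OC`) differs from compound 2 by 3-sulfamoylphenyl in place of 4-(trifluoromethyl)phenyl on an amide-type nitrogen in one place: 3-sulfamoylphenyl in place of 4-(trifluoromethyl)phenyl on an amide-type nitrogen. Within the data shown here, no measured step tests a sulfamoyl group. Among the measured compounds shown here, the only guide is a 1.0-fold higher number from compound 1 to compound 2 (0.00 log units; within the scatter) for shifting the trifluoromethyl group, so no change beyond the scatter is expected in this assay here. The expected step is a 1.1-fold higher number from compound 2 to compound 3 (0.06 log units; within the scatter) as a rough estimate. Compound 3 is estimated at 25000 nM with a range of 10000 nM to 60000 nM in this assay when measured.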

Compound 3, half-maximal cytotoxic concentration: 67800 nM
Compound 3: the middle estimate sits 2.7-fold (0.43 log units) below what was measured; the measured number lies above the stated range.
By their numbers in this assay, from the lowest: compounds 1 and 2 (each within the scatter of the next); then compound 3.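

On this amide-type nitrogen, the choice of aryl group can shift the number in this assay: moving the trifluoromethyl group left it level, but 3-sulfamoylphenyl in place of 4-(trifluoromethyl)phenyl raises it (a 3.1-fold higher number from compound 2 to compound 3 (0.49 log units; beyond the scatter)). Sulfamoyl in place of trifluoromethyl on an aromatic carbon, with nothing else changed, gives the same kind of rise (a 3.1-fold higher number from compound 1 to compound 3 (0.49 log units; beyond the scatter)). No measurement here explains this rise. From the compounds shown here alone, whether a carboxylic acid or an amine on this phenyl ring would raise the number too remains open, as does whether moving the sulfamoyl group would matter.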